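Phenyl for trimethoxyphenyl at a ketone carbon

The compounds below may be only part of what the source reports. "The series", "measured", "known", "first", "only" and "open" are said of these compounds alone.

Compound 1 `COc1cc(C(=O)C2Sc3nnc(-c4cc(OC)c(OC)c(OC)c4)n3NC2c2ccco2)cc(OC)c1OC` gives 52200 nM in a functional assay on PC-3 cells (Homo sapiens) for cytotoxicity, read by MTT assay, with a stated time of 48 h; on this read-out higher numbers stand for weaker inhibition and lower numbers for stronger inhibition.
Compound 2 `COc1cc(-c2nnc3n2NC(c2ccco2)C(C(=O)C2CC2)S3)cc(OC)c1OC` gives 95200 nM in this assay.

Compound 1 holds the lowest of the two numbers, and its nearest neighbour is compound 2, separated by a 1.8-fold higher number from compound 1 to compound 2 (0.26 log units; within the scatter). Compound 3 `COc1cc(-c2nnc3n2NC(c2ccco2)C(C(=O)c2ccccc2)S3)cc(OC)c1OC` differs from compound 1 by phenyl in place of 3,4,5-trimethoxyphenyl on a carbonyl carbon. For the measured compounds named here, the only measured step at that carbonyl carbon, a 1.8-fold higher number from compound 1 to compound 2 (0.26 log units; within the scatter), stayed within the scatter, so the expected step is a 1.3-fold higher number from compound 1 to compound 3 (0.13 log units; within the scatter), with no change beyond the scatter in this assay. Compound 3 is therefore estimated at 70000 nM, with a range from 25000 nM to 200000 nM.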

Compound 3, half-maximal inhibitory concentration: 64300 nM
Compound 3: the middle estimate sits 1.1-fold (0.04 log units) above what was measured; the measured number falls inside the stated range.
By their numbers in this assay, from the lowest: compounds 1, 3 and 2 (each within the scatter of the next).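

Phenyl in place of 3,4,5-trimethoxyphenyl on the carbonyl carbon gives a 1.2-fold higher number from compound 1 to compound 3 (0.09 log units; within the scatter), and phenyl in place of cyclopropyl gives a 1.5-fold lower number from compound 2 to compound 3 (0.17 log units; within the scatter). Now that a plain aromatic ring has joined the other two groups, this assay still cannot tell any of the three apart at this position. No supporting data are available to explain this flat result.

Still open, on these data alone, is whether a different kind of group on this carbonyl carbon, such as an amine or a carboxylic acid, would move the number beyond the scatter.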